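The source may hold more compounds than are shown below. What is called first, only, known or untested is meant among the compounds shown, and "the series" means these compounds.

Three compounds have been measured:
compound 1 `O=C(Nc1cccc(-n2cc(-c3ccncc3)c(-c3cc(O)cc(Cl)c3)n2)c1)Nc1ccc(Cl)c(C(F)(F)F)c1` with -13.5%
compound 2 `COc1cc(Cl)cc(-c2nn(-c3cccc(NC(=O)Nc4ccc(Cl)c(C(F)(F)F)c4)c3)cc2-c2ccncc2)c1` with 23.6%
compound 3 `O=C(Nc1cccc(-n2cc(-c3ccncc3)c(-c3cc(O)cc(Cl)c3)n2)c1)c1cc(C(F)(F)F)cc(C(F)(F)F)c1` with 63.6%

All three were tested in a functional assay on SK-MEL-28 cells (Homo sapiens) for inhibition, read by sulforhodamine B assay, with a stated time of 48 h, tested at 10 uM; on this read-out lower numbers stand for a stronger effect and higher numbers for a weaker effect at the one concentration tested. Compound 1 and compound 2 share one core and differ in a single place: methyl in place of hydrogen on an oxygen on an aromatic ring. That change gave a number 37.1 percentage points higher from compound 1 to compound 2 (beyond the scatter), so compound 2, the methoxy compound, shows the weaker effect of the pair. Compound 3 carries a different core from compound 1; the difference between the two cores is not broken down here. Compound 3 gives the highest number of the three, beyond the scatter from both others.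

Compound 4 `COc1cc(Cl)cc(-c2nn(-c3cccc(NC(=O)c4cc(C(F)(F)F)cc(C(F)(F)F)c4)c3)cc2-c2ccncc2)c1` has not yet been measured. It differs from compound 3 by methyl in place of hydrogen on an oxygen on an aromatic ring, the same change as between compound 1 and compound 2, in the same place. The step from compound 3 to compound 4 is therefore expected to go the same way but to be smaller, a number 21.4 percentage points higher from compound 3 to compound 4 (beyond the scatter), because compound 3 already gives 63.6% and the read-out leaves less room upward. Compound 4 is thus estimated at 85%, with a likely range from 62% to 105%.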

Compound 4, a percentage reported as activity, at one concentration (the size of the read-out at that concentration, not a potency): 78.8%
Compound 4: the middle estimate sits 6.2 percentage points above what was measured; the range from low to high includes it.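

In this assay replacing the hydroxy group with a methoxy group on the second core again raises the number (a number 15.2 percentage points higher from compound 3 to compound 4 (beyond the scatter)), which means a weaker effect, as it did on the first core. The direction of the change therefore carries from one core to the other in these two pairs, but its size does not: the same change on two cores in this assay, a number 37.1 percentage points higher (beyond the scatter) from compound 1 to compound 2 and a number 15.2 percentage points higher (beyond the scatter) from compound 3 to compound 4, 21.9 percentage points apart, beyond the scatter of two such steps. Two pairs cannot show what sets the size of the step on each core, nor whether the same direction would appear on a third core.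

The compounds shown carry only a hydroxy or a methoxy group at this place, so it remains open how an ethoxy group, a longer chain on the oxygen, or an amine in place of the hydroxy group would behave. Each number also comes from a single concentration, which leaves open how the compounds would compare across a range of concentrations.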